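The source may report more compounds than this note shows. Statements on the series, on what has been measured and on what is new or still open speak of the compounds shown alone.

Measured so far: compound 1 `COc1ccc(N(C)c2nc(C)nc3ccccc23)cc1C(=O)NCC[Se]C#N` gives 179 nM in a functional assay on HepG2 cells (Homo sapiens) for inhibition, read by MTT assay, with a stated time of 48 h; a lower number here means a stronger inhibitor, a higher number a weaker inhibitor; compound 2 `COc1ccc(N(C)c2nc(C)nc3ccccc23)cc1OCCCCC[Se]C#N` gives 5210 nM.

Compound 1 stands lowest of the two numbers, and its nearest neighbour is compound 2, with a 29-fold higher number from compound 1 to compound 2 (1.46 log units; beyond the scatter). Compound 3 `COc1ccc(N(C)c2nc(C)nc3ccccc23)cc1C(=O)OCCCCCC[Se]C#N` differs from compound 1 by a group of 10 heavy atoms (7 carbon, 1 nitrogen, 1 oxygen, 1 selenium; no ring) in place of a group of 6 heavy atoms (3 carbon, 2 nitrogen, 1 selenium; no ring), on a carbonyl carbon. For the measured compounds named here, the only step that bears on this, from compound 1 to compound 2, also moved to a longer chain and gave a large rise, so a weaker inhibitor is expected for compound 3, though less surely since a different place is changed. Compound 3 is therefore estimated at 1500 nM, within 400 nM to 6000 nM, a step of an 8.4-fold higher number from compound 1 to compound 3 (0.92 log units; beyond the scatter).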

Compound 3, half-maximal inhibitory concentration: 2650 nM
Compound 3: the middle estimate sits 1.8-fold (0.25 log units) below what was measured; measured number inside the range.
By their numbers in this assay, from the lowest: compound 1; then compounds 3 and 2 (each within the scatter of the next).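

In this assay keeping the carbonyl on the aromatic carbon does not hold the low number of compound 1: on that carbonyl carbon, the group of 10 heavy atoms in place of the group of 6 gives a 15-fold higher number from compound 1 to compound 3 (1.17 log units; beyond the scatter) with the rest of the structure unchanged. This one change both removes the hydrogen-bond donor and lengthens the chain, so the step cannot be assigned to either alone. No measurement at hand explains the rise. Going by these compounds, whether an amide carrying a longer chain, or an ester carrying a shorter chain, would come closer to compound 1 stays open.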